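This account rests on a few compounds, and the source may have more. Where it says the series, first, only, none or still open, it means among the compounds named here.

Values in a physicochemical assay for solubility, read by nephelometry, in phosphate buffer, at pH 7.4 (on this read-out higher numbers stand for higher solubility and lower numbers for lower solubility), so far:
- compound 1 `COc1cc(/C=C/C(=O)NCCn2c(CNC3CCN(C)CC3)cc3ccccc32)cc(OC)c1OC` gives 180000 nM
- compound 2 `Cc1cc2ccccc2n1CCNC(=O)/C=C/c1ccc(OCCCO)cc1` gives 66000 nM

Of these two numbers, compound 2 holds the lower (66000 nM) and compound 1 stands higher, by a gap beyond the scatter. Compound 3 `Cc1cc2ccccc2n1CCNC(=O)/C=C/c1ccc(OCCO)cc1` is not yet measured. It departs from compound 2 by a single change (hydroxy in place of hydroxymethyl on a saturated chain carbon, two bonds along the chain from an oxygen on an aromatic ring): hydroxy in place of hydroxymethyl on a saturated chain carbon, two bonds along the chain from an oxygen on an aromatic ring. The same difference reads 3-hydroxypropoxy to 2-hydroxyethoxy. Within the data shown here, no measured pair differs in one place only, so no measurement sizes this change. In this assay the expectation is a step no larger than the scatter, if anything slightly upward. The estimated 1.1-fold higher number from compound 2 to compound 3 (0.06 log units; within the scatter) is correspondingly small. For compound 3 the expected value is 75000 nM within an estimated range (38000 nM to 150000 nM) until the measurement is in.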

Compound 3, solubility: 68000 nM
The estimate for compound 3 lay 1.1-fold (0.04 log units) above the measured number; the range from low to high includes it.
By their numbers in this assay, from the lowest: compounds 2 and 3 (each within the scatter of the next); then compound 1.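

In this assay, the series now has its first step between compounds that differ in one place, and it reads a 1.0-fold higher number from compound 2 to compound 3 (0.01 log units; within the scatter). At this place, on a saturated chain carbon, two bonds along the chain from an oxygen on an aromatic ring, hydroxy in place of hydroxymethyl therefore gives no difference that can be told from the scatter, and 3-hydroxypropoxy and 2-hydroxyethoxy read alike on the shared core. Nothing in hand accounts for this result, and one pair sets no trend for the chain.

From the compounds shown here alone, whether a longer chain, or an amine or a carboxylic acid in place of the hydroxy, would read differently in this assay stays open. Also open, going by these compounds, is whether the same change would read alike on the core of compound 1.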